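A few compounds are considered here, and "the series" means these few. Any claim that something is new, unique, unknown or untested is made for them only; others in the source may bear on it.

Compound 1 `C[S+]([O-])/C=C/c1cc(=O)c2ccccc2o1` is the parent of a small set of three measured compounds. In a functional assay on DLD-1 cells (Homo sapiens) for cytotoxicity, with a stated time of 48 h (a lower number here means a stronger inhibitor, a higher number a weaker inhibitor), compound 1 gives 8000 nM, the highest of the three numbers, though all three sit close together. Compound 2 `Cc1ccc2oc(/C=C/[S+](C)[O-])cc(=O)c2c1` gives 7000 nM in this assay, and compound 3 `CCCCC(=O)Oc1ccc2oc(/C=C/[S+](C)[O-])cc(=O)c2c1` gives 6700 nM, so replacing a hydrogen on the aromatic carbon of the shared core has so far left the numbers where they were: a 1.1-fold lower number from compound 1 to compound 2 (0.06 log units; within the scatter) and a 1.2-fold lower number from compound 1 to compound 3 (0.08 log units; within the scatter).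

Compound 4 `C[S+]([O-])/C=C/c1cc(=O)c2cc(Br)ccc2o1` has not yet been measured. It differs from compound 1 in one place: bromo in place of hydrogen on an aromatic carbon. This is again a single small group entering on an aromatic carbon of the six-membered carbon ring of the core, so the steps from compound 1 to compound 2 and from compound 1 to compound 3 are the ones that bear on it. Both were within the scatter, and there is no measured case in which a change on this ring moved the number beyond it. Compound 4 is therefore expected to give a number close to that of compound 1 in this assay, with a step of a 1.1-fold lower number from compound 1 to compound 4 (0.06 log units; within the scatter) that stays within the scatter. The estimate for compound 4 is 7000 nM, in a range from 3500 nM to 14000 nM.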

Compound 4, half-maximal inhibitory concentration: 4500 nM
Compound 4: the middle estimate sits 1.6-fold (0.19 log units) above what was measured, within the range that was stated.
By their numbers in this assay, from the lowest: compounds 4, 3, 2 and 1 (each within the scatter of the next).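

Among these compounds, with bromo in place of hydrogen, a 1.8-fold lower number from compound 1 to compound 4 (0.25 log units; within the scatter) is the largest step so far from the parent in this assay, yet even this step stays within the scatter, so a single bromine atom on this aromatic carbon has not clearly changed the number. Measured against the other groups at this position, bromo gives a 1.5-fold lower number from compound 3 to compound 4 (0.17 log units; within the scatter) and a 1.6-fold lower number from compound 2 to compound 4 (0.19 log units; within the scatter), so it cannot be told apart from (butylcarbonyl)oxy or from methyl, and all four compounds remain one group with no real order among them. No measurement shown here offers a reason for these small steps.

What remains open is whether a quite different group on this carbon, such as an amine or a carboxylic acid, would move the number beyond the scatter, since hydrogen, methyl, bromo and (butylcarbonyl)oxy are the only groups shown here. The compounds also leave open whether the number responds to changes elsewhere on the shared core or in the sulfur-bearing side chain, which is the same in all four.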